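The compounds below may be only part of what the source reports. "The series", "measured", "known", "first", "only" and "open" are said of these compounds alone.

Measured compounds in the series:

- compound 2 `Nc1cccc2c(-c3cccc(NC(=O)c4cc(Cl)cc(C(F)(F)F)c4)c3)ccnc12`: 18500 nM
- compound 1 `Nc1cccc2c(-c3cccc(NC(=O)c4ccc(F)c(C(F)(F)F)c4)c3)ccnc12`: 10400 nM
- compound 3 `Cc1cc(C(=O)Nc2cccc(-c3ccnc4c(N)cccc34)c2)c(C)o1`: the assay reports only a limit for compound 3, > 20000 nM

In a functional assay on A375P cells (Homo sapiens) for antiproliferative activity, read by MTT assay, with a stated time of 48 h (on this read-out higher numbers stand for weaker inhibition and lower numbers for stronger inhibition), compound 2 gives 18500 nM, the highest of the two numbers shown. Compound 1 gives 10400 nM in this assay, and the gap between compound 1 and compound 2 lies within the scatter, so neither is placed above the other. For compound 3 the read-out is a limit, not a number, and it sits at the limit of > 20000 nM in this assay, at which 1 of the 3 values shown sits. Among these three compounds the aryl amide part varies while the amine on the shared core is kept; no step between measured compounds is available.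

Compound 4 `CC(=O)Nc1cccc2c(-c3cccc(NC(=O)c4cc(Cl)cc(C(F)(F)F)c4)c3)ccnc12` is not yet measured. It differs from compound 2 only in one place:

acetyl in place of hydrogen on a nitrogen on an aromatic ring

For the measured compounds named here, no measured step shows the effect of such a change, so the expectation for this assay rests on compound 2 alone: a step of no more than the usual scatter, if anything toward a weaker inhibition, a 1.2-fold higher number from compound 2 to compound 4 (0.08 log units; within the scatter). Compound 4 is estimated to give 22000 nM in this assay, with an expected range from 8000 nM to 60000 nM, and a real chance that only a limit is reported.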

Compound 4, half-maximal inhibitory concentration: 6200 nM
Estimate against measurement, compound 4: 3.5-fold (0.55 log units) above; the measured number lies below the stated range.
By their numbers in this assay, from the lowest: compounds 4, 1 and 2 (each within the scatter of the next, the first and the last beyond it). At a limit, above all of these: compound 3.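

In this assay, amino to acetamido on the shared core gives a 3.0-fold lower number from compound 2 to compound 4 (0.47 log units; beyond the scatter) and shows that this nitrogen need not carry a free amine for the antiproliferative activity seen with this aryl amide. For the compounds shown here, this is the only measured change at this position, and the modest step runs toward stronger inhibition, which the changes in the aryl amide part alone could not show. Nothing in the data at hand accounts for this step.

On these data alone, whether the step belongs to the acetyl itself or to acylation of this nitrogen in general stays open, and a longer acyl chain such as propionyl, a methanesulfonyl group or a dimethylamino group here would help to separate the two. Also open, as far as these compounds go, is whether acetyl in place of hydrogen on this nitrogen gives a similar step with other aryl amides, such as that of compound 1.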